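The compounds below may be only part of what the source reports. "The series", "measured", "known", "first", "only" and "open" are said of these compounds alone.

Measured so far: compound 1 `CCCc1ccc(NC(=O)N[C@H](C)c2ccccc2)cc1` gives 33% in an ADME assay on the whole organism with Oryza sativa as the target, tested at 0.1 uM; on this read-out higher numbers stand for a weaker effect at the one concentration tested and lower numbers for a stronger effect; compound 2 `CCCc1ccc(NC(=O)N[C@@H](C)c2ccccc2)cc1` gives 97%; compound 3 `CCCCCCCc1ccc(NC(=O)N[C@@H](C)c2ccccc2)cc1` gives 100%.

Among these three, compound 1 stands lowest, which on this read-out means the strongest effect; compound 2 sits a number 64 percentage points higher from compound 1 to compound 2 (beyond the scatter), and compound 3 lies within the scatter of compound 2. The large step between compound 1 and compound 2 rests only on configuration (the fact that compounds 1 and 2 differ only in the configuration as drawn). Compound 4 `C[C@@H](NC(=O)Nc1ccc(C(F)(F)F)cc1)c1ccccc1` keeps the configuration of compound 1 and alters the group on the aromatic ring: trifluoromethyl in place of propyl on an aromatic carbon. Within the data shown here, the one measured step touching that part of the molecule, a number 3 percentage points higher from compound 2 to compound 3 (within the scatter), lengthened the chain and stayed within the scatter. Trifluoromethyl is not an alkyl chain, so that step is only a loose guide. Compound 4 is therefore expected near compound 1, with a number 9 percentage points higher from compound 1 to compound 4 (within the scatter) as the estimated shift. The estimate for compound 4 is 42%, ranging from 15% to 80%.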

Compound 4, a percentage reported as activity, at one concentration (the size of the read-out at that concentration, not a potency): 93%
The estimate for compound 4 lay 51 percentage points below the measured number, outside the stated range (above it).
By their numbers in this assay, from the lowest: compound 1; then compounds 4, 2 and 3 (each within the scatter of the next).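

Configuration is not the only feature that counts in this series: with the configuration of compound 1 kept, trifluoromethyl in place of propyl gives a number 60 percentage points higher from compound 1 to compound 4 (beyond the scatter), so the group on this aromatic carbon matters too. The earlier chain change, a number 3 percentage points higher from compound 2 to compound 3 (within the scatter), was made in the opposite configuration and could not show this. Nothing available explains why this exchange has so large an effect.

Going by these compounds, whether a butyl group, a methoxy group or an amine on this carbon would preserve the effect of compound 1 remains open. So does whether trifluoromethyl would change anything in the opposite configuration.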